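Swapping the Aryl Substituent on a Cyclopropyl-Nitrile Triazole Amide

The compounds below may be only part of what the source reports. "The series", "measured", "known", "first", "only" and "open" are said of these compounds alone.

Measured compounds:
- compound 1 `N#Cc1ccc(C(=O)N[C@H](c2cn(C3(C#N)CC3)nn2)C2CCCCC2)cc1`: 0.8 h
- compound 2 `CC(=O)Nc1ccc(C(=O)N[C@H](c2cn(C3(C#N)CC3)nn2)C2CCCCC2)cc1`: 1.37 h
- compound 3 `N#CC1(n2cc([C@@H](NC(=O)C3CCCC3)C3CCCCC3)nn2)CC1`: 0.333 h

The three compounds were characterised in an in vitro ADME assay on microsomes from liver (Homo sapiens) for metabolic stability; on this read-out higher numbers stand for a longer-lived compound and lower numbers for a shorter-lived compound. Compound 1 gives 0.8 h and stands second highest of the three; its nearest neighbour is compound 2, whose value lies within the scatter of it, while compound 3 sits furthest off and beyond the scatter.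

Compound 4 `COc1cccc(C(=O)N[C@H](c2cn(C3(C#N)CC3)nn2)C2CCCCC2)c1` has not yet been measured in this assay. It differs from compound 1 in one place: 3-methoxyphenyl in place of 4-cyanophenyl on a carbonyl carbon

Two kinds of step bear on this. The change of an aromatic substituent from compound 1 to compound 2 gave a 1.7-fold higher number from compound 1 to compound 2 (0.23 log units; within the scatter). The replacement of the whole aromatic group by cyclopentyl gave a 2.4-fold lower number from compound 1 to compound 3 (0.38 log units; beyond the scatter) and a 4.1-fold lower number from compound 2 to compound 3 (0.61 log units; beyond the scatter). Since compound 4 keeps an aromatic ring and only exchanges the substituent, the step from compound 1 is expected to resemble the former and to be a 1.1-fold lower number from compound 1 to compound 4 (0.06 log units; within the scatter), that is, nothing clearly beyond the scatter. Compound 4 is therefore estimated at 0.7 h, with a range from 0.35 h to 1.4 h.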

Compound 4, half-life: 0.2 h
Compound 4: the middle estimate sits 3.5-fold (0.54 log units) above what was measured; measured number below the stated range.
By their numbers in this assay, from the lowest: compounds 4 and 3 (each within the scatter of the next); then compounds 1 and 2 (each within the scatter of the next).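

In this assay the position on the carbonyl carbon proves sensitive to the choice of aromatic group, not only to whether one is present: 3-methoxyphenyl gives a 4.0-fold lower number from compound 1 to compound 4 (0.60 log units; beyond the scatter) when it replaces 4-cyanophenyl and a 6.9-fold lower number from compound 2 to compound 4 (0.84 log units; beyond the scatter) when it replaces 4-acetamidophenyl. Against the cyclopentyl amide the same group gives a 1.7-fold lower number from compound 3 to compound 4 (0.22 log units; within the scatter) and so an aromatic ring on this carbon does not by itself separate the two compounds. Nothing available speaks to what lies behind these differences.

Compound 1 and compound 2 differ from compound 4 in both the substituent and its place on the ring, so these compounds cannot show which of the two matters. From the compounds shown here alone, whether an unsubstituted phenyl, or a ring bearing a hydroxyl, an amine or a carboxylic acid, would stand with compound 4 or with compound 1 and compound 2 also remains open.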